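Compound 3 to compound 4: an aryl swap at the limit

The source may report more compounds than this note shows. Statements on the series, on what has been measured and on what is new or still open speak of the compounds shown alone.

Values in a functional assay on NCI-H1993 cells (Homo sapiens) for inhibition, read by CCK-8 assay, with a stated time of 72 h; a higher number here means a weaker inhibitor, a lower number a stronger inhibitor:
- compound 1 `CCC(c1ccc2ncccc2c1F)n1cnc2ncc(-c3cn[nH]c3)nc21`: "not determined" (no result reported)
- compound 2 `CC(c1cc(F)c2ncccc2c1)n1cnc2ncc(-c3ccccc3)nc21`: > 10000 nM
- compound 3 `CN(C)c1cccc(-c2cnc3ncn(Cc4ccc5ncccc5c4)c3n2)c1`: > 10000 nM

Compound 1 has no usable result, so it offers no guidance. In this assay compound 3 reads > 10000 nM, which is a limit and not a number. Compound 2 reads > 10000 nM, which is also a limit. Going by the values given here, the series so far therefore comes down to one feature: the limit of > 10000 nM in this assay, at which 2 of the 3 values shown sit. Among the compounds with values here, no step between measured compounds can be read from this.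

Compound 4 `FC(F)(F)c1ccc(-c2cnc3ncn(Cc4ccc5ncccc5c4)c3n2)cc1` keeps the core and the side group of compound 3 and carries 4-(trifluoromethyl)phenyl in place of 3-(dimethylamino)phenyl on an aromatic carbon. The counted difference is 4-(trifluoromethyl)phenyl in place of 3-(dimethylamino)phenyl on an aromatic carbon.

Within the data shown here, with no measured step to scale from, no change beyond the usual scatter is expected in this assay, and no direction is favoured. The expected step that the limit leaves unreadable from compound 3 to compound 4 is only a nominal one, as its starting point is a limit. The most likely outcome is that this assay again returns a limit and not a number. For compound 4 the estimated value is 12000 nM, with an expected range from 3000 nM to 40000 nM.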

Compound 4, half-maximal inhibitory concentration: > 10000 nM
Compound 4 was reported as a limit; the forecaster's own chance of this, stated with the estimate: 75%; the middle value is on the limit's open side.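

In this assay compound 4 gives > 10000 nM, which is a limit and not a number. Compound 3 gives > 10000 nM, also a limit, so no step can be read between compound 3 and compound 4. The compounds shown leave open whether any group on the shared core gives a measurable number in this assay: the limit of > 10000 nM in this assay, at which 3 of the 4 values shown sit.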